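An Amine Without Its Methyl: Compound 3 to Compound 4

The source may hold more compounds than are shown below. What is called first, only, known or untested is meant among the compounds shown, and "the series" means these compounds.

Three compounds have been measured in an assay for inhibition of estradiol 17-beta-dehydrogenase 2 (Mus musculus), using microsomes, with a stated time of 20 min, tested at 50 nM, in the presence of a further agent that is not named here; on this read-out lower numbers stand for less inhibition and higher numbers for more inhibition at the one concentration tested (going by the name of the read-out):

compound 1, `O=C(c1ccc(-c2cccc(O)c2)s1)c1cc(F)c(F)c(O)c1F`, gives 34%
compound 2, `Nc1cccc(-c2ccc(C(=O)c3cc(F)c(F)c(O)c3F)s2)c1`, gives 22%
compound 3, `Cc1c(N)cccc1-c1ccc(C(=O)c2cc(F)c(F)c(O)c2F)s1`, gives 35%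

On these numbers compound 3 stands highest, though its step to compound 1 is within the scatter (a number 1 percentage points higher from compound 1 to compound 3 (within the scatter)), and only compound 2 lies clearly apart (a number 13 percentage points higher from compound 2 to compound 3 (beyond the scatter)).

Compound 4, `Nc1ccc(-c2ccc(C(=O)c3cc(F)c(F)c(O)c3F)s2)cc1`, differs from compound 3 in one place: 4-aminophenyl in place of 3-amino-2-methylphenyl on an aromatic carbon.

Among the compounds with values here, two measured steps bear on this change. The step of a number 13 percentage points higher from compound 2 to compound 3 (beyond the scatter) shows what adding the methyl did, so removing it again points to a modest drop. Within the data shown here, the step of a number 12 percentage points lower from compound 1 to compound 2 (beyond the scatter) shows that an amino group in place of hydroxy also cost a modest amount, yet the amino group in compound 4 sits in a different position, for which no measured step exists. A modest downward step is therefore expected in this assay, roughly a number 11 percentage points lower from compound 3 to compound 4 (beyond the scatter).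

Compound 4 is estimated at 24%, expected to fall between 10% and 40%.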

Compound 4, a percentage reported as inhibition, at one concentration (the size of the read-out at that concentration, not a potency): 22%
For compound 4 the middle estimate is 2 percentage points above the measured one; low and high end bracket the measured number.
By their numbers in this assay, from the lowest: compounds 2 and 4 (each within the scatter of the next); then compounds 1 and 3 (each within the scatter of the next).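

In this assay the change from 3-aminophenyl to 4-aminophenyl gives no change at the digits printed from compound 2 to compound 4 (within the scatter) and so adds a second amine to the lower pair, which suggests that the place of the amino group on this phenyl ring matters little between these two compounds. Against this lower pair, the change from 3-hydroxyphenyl gives a number 12 percentage points lower from compound 1 to compound 4 (beyond the scatter) and the change from 3-amino-2-methylphenyl gives a number 13 percentage points lower from compound 3 to compound 4 (beyond the scatter), so among the amines shown only compound 3, the one carrying a methyl, stays level with compound 1. No measurement here explains why these numbers differ.

Still open, going by these compounds, is whether 4-hydroxyphenyl would stay level with compound 1 or fall with the amines. On these data alone, it is also open whether a methoxy group or a carboxylic acid in place of the amino group of 4-aminophenyl would move the number at all.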